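Propyl to trifluoromethyl on the outer ring of a biaryl amide

This account rests on a few compounds, and the source may have more. Where it says the series, first, only, none or still open, it means among the compounds named here.

Measured compounds:
- Compound 1, `CC[C@H](C)[C@H](N)CN(C(=O)[C@@H]1C[C@H]1c1ccccc1)c1ccc(-c2ccccc2)cc1`: 230 nM; 800 nM (2 entries)
- Compound 2, `CCCc1ccc(-c2ccc(N(C[C@@H](N)[C@@H](C)CC)C(=O)[C@@H]3C[C@H]3c3ccccc3)cc2)cc1`: 61 nM

In a functional assay for agonist activity at G protein-coupled receptor 88 (Homo sapiens), read by HTRF and cAMP accumulation (on this read-out lower numbers stand for an effect already at smaller amounts and higher numbers for an effect only at larger amounts of compound), compound 2 gives 61 nM, the only single number among the compounds shown, and it is accompanied by one further entry that carries no number. Compound 1, which in this assay gives 230 nM; 800 nM (2 entries), shows how widely repeated entries of one compound can fall, as the two entries of the several entries of compound 1 in this assay, 230 nM; 800 nM (2 entries) lie apart by more than the usual scatter. Going by the values given here, no step between compound 1 and compound 2 has been worked out, so only their two values stand side by side.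

Compound 3, `CC[C@H](C)[C@H](N)CN(C(=O)[C@@H]1C[C@H]1c1ccccc1)c1ccc(-c2ccc(C(F)(F)F)cc2)cc1`, has not yet been measured. It differs from compound 2 in one place: trifluoromethyl in place of propyl on an aromatic carbon. Among the compounds with values here, no measured pair shows the effect of this exchange. The estimate therefore leans on the value of compound 2, 61 nM, and on the spread seen for compound 1. Compound 3 is expected to land somewhat higher, a step of a 2.5-fold higher number from compound 2 to compound 3 (0.39 log units; beyond the scatter) that may not clearly exceed the scatter. The expected value of compound 3 in this assay is 150 nM, between 40 nM and 550 nM.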

Compound 3, half-maximal effective concentration: 340 nM
Compound 3: the middle estimate sits 2.3-fold (0.36 log units) below what was measured, and the stated range covers the measured number.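

In this assay, this position on the outer ring, para to a large group, proves sensitive to which group it carries. Trifluoromethyl in place of propyl gives a 5.6-fold higher number from compound 2 to compound 3 (0.75 log units; beyond the scatter), a modest step, but one that shows the number of compound 2 is not kept when propyl is exchanged. Compound 1 carries neither group at this position, and the value of compound 3 falls inside the span of its entries, so trifluoromethyl cannot be set apart from the bare outer ring, and of the two groups only propyl, in compound 2 at 61 nM, gives a number outside that span: the several entries of compound 1 in this assay, 230 nM; 800 nM (2 entries)

The compounds shown do not tell what separates propyl from trifluoromethyl, as they offer a single exchange between the two groups and no measured property of either. A butyl chain, a methoxy group or an amine at the same position would show whether the lower number of compound 2 belongs to propyl alone or extends to other groups there.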